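Carboxyphenoxy Replacement in a Bile Acid Receptor Series

The compounds below may be only part of what the source reports. "The series", "measured", "known", "first", "only" and "open" are said of these compounds alone.

Compound 1 `Cc1nn(-c2ccccc2C(F)(F)F)c2c1C(c1ccc(Oc3ccccc3)cc1)SC(C)C(=O)N2`: 2000 nM
Compound 2 `Cc1ccccc1-n1nc(C)c2c1NC(=O)[C@H](C)S[C@@H]2c1ccc(-c2ccco2)cc1`: 3600 nM
Compound 3 `Cc1ccccc1-n1nc(C)c2c1NC(=O)[C@H](C)S[C@@H]2c1ccc(/C=C/c2ccccc2)cc1`: "not active" (no number reported)

In an assay on isolated protein for agonist activity at Bile acid receptor (Homo sapiens), read by AlphaScreen, with a stated time of 30 min (a lower number here means that less compound is needed, a higher number that more compound is needed for the effect), compound 1 gives 2000 nM. Compound 2 gives 3600 nM in this assay, and the two values lie within the scatter of each other. Compound 3 gives "not active" (no number reported) in this assay, so no number is available for it. Compound 4 `Cc1ccccc1-n1nc(C)c2c1NC(=O)[C@H](C)S[C@@H]2c1ccc(Oc2ccccc2C(=O)O)cc1` differs from compound 3 by one change: 2-carboxyphenoxy in place of 2-phenylethenyl on an aromatic carbon. Since compound 3 has no number, no step size can be stated; an acid-bearing group entering at this position is expected to restore measurable activity. The half-maximal effective concentration of compound 4 in this assay is estimated at 1000 nM, with a range from 250 nM to 5000 nM.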

Compound 4, half-maximal effective concentration: "not active" (no number reported)
Compound 4: no number reported; the estimate stays without a comparison.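

Compound 3 and compound 4 both come without a number, so no step can be read between them. The compounds shown leave open what separates them from compound 2, which has a number. No evidence bears on this result.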